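Phenethyl in place of furan-2-yl on the shared core

This account rests on a few compounds, and the source may have more. Where it says the series, first, only, none or still open, it means among the compounds named here.

Compound 1 `O=C(Nn1c(-c2cccc([N+](=O)[O-])c2)nc2c(-c3ccc(Cl)cc3)n[nH]c2c1=O)c1cccnc1`: 31%
Compound 2 `O=C(Nn1c(-c2cccc([N+](=O)[O-])c2)nc2c(-c3ccco3)n[nH]c2c1=O)c1cccnc1`: 1.66%

In a functional assay on DU-145 cells (Homo sapiens) for cytotoxicity, read by sulforhodamine B assay, with a stated time of 2 days, tested at 100 uM (a lower number here means less inhibition, a higher number more inhibition at the concentration tested (going by the name of the read-out)), compound 2 stands lowest of the two numbers measured. Within the data shown here, the only measured step is a number 29.3 percentage points lower from compound 1 to compound 2 (beyond the scatter), a modest fall beyond the scatter. Compound 3 `O=C(Nn1c(-c2cccc([N+](=O)[O-])c2)nc2c(CCc3ccccc3)n[nH]c2c1=O)c1cccnc1` differs from compound 2 by phenethyl in place of furan-2-yl on an aromatic carbon. Among the measured compounds shown here, no measured step involves phenethyl, so the one step shows only that the group at this position changes the read-out. A partial rise is expected, a number 13.3 percentage points higher from compound 2 to compound 3 (beyond the scatter), and the estimate for compound 3 is 15%, with a range from 0% to 40%.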

Compound 3, a percentage reported as inhibition, at one concentration (the size of the read-out at that concentration, not a potency): 22.5%
The estimate for compound 3 lay 7.5 percentage points below the measured number, and the stated range covers the measured number.
By their numbers in this assay, from the lowest: compound 2; then compounds 3 and 1 (each within the scatter of the next).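

In this assay, phenethyl in place of furan-2-yl gives a number 20.8 percentage points higher from compound 2 to compound 3 (beyond the scatter), so the low number of compound 2 does not carry over to this larger group with its six-membered aromatic ring. Phenethyl in place of 4-chlorophenyl gives a number 8.5 percentage points lower from compound 1 to compound 3 (within the scatter), so these two groups cannot be told apart here, and only furan-2-yl stands apart from both. No measurement shown here explains this difference.

Going by these compounds, whether an amine or a carboxylic acid at this position would stand with compound 2 or with compound 1 and compound 3 remains open. So does the effect of a longer chain ending in a phenyl ring.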